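Working notes: compound 2 to compound 3

A few compounds are considered here, and "the series" means these few. Any claim that something is new, unique, unknown or untested is made for them only; others in the source may bear on it.

Measured compounds:
- Compound 1 `O=C(NCCCCn1cccn1)c1cccc(C2SCC(=O)N2c2cccnc2)c1`: in a functional assay on HOS-TE85 cells (Homo sapiens) for inhibition, read by CCK-8 assay, with a stated time of 72 h (on this read-out higher numbers stand for weaker inhibition and lower numbers for stronger inhibition), compound 1 reports > 1000 nM, which is a limit of the assay and not a number (the limit of > 1000 nM in this assay, at which 1 of the 2 values shown sits).
- Compound 2 `Cc1cccc(N2C(=O)CSC2c2cccc(C(=O)NCCCCc3ccccc3)c2)c1`: in this assay compound 2 gives 93.2 nM.

Compound 2 thus carries the only number shown in this series; the one further value is a limit. For the measured compounds named here, no two measured compounds differ in a single place, so no measured step is available to calibrate the change that follows.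

Compound 3 `COc1c(F)cccc1N1C(=O)CSC1c1cccc(C(=O)NCCCCc2ccccc2)c1` is the next entry. Against compound 2 the difference is 3-fluoro-2-methoxyphenyl in place of 3-methylphenyl on an amide-type nitrogen in a ring. Nothing measured speaks to a change of this kind, so the expectation rests on compound 2 alone. The step from compound 2 to compound 3 is expected to be a 1.7-fold higher number from compound 2 to compound 3 (0.23 log units; within the scatter), a shift toward weaker inhibition that may well fall within the usual scatter. For compound 3 in this assay the estimate is 160 nM, with a range from 40 nM to 800 nM.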

Compound 3, half-maximal inhibitory concentration: 26.2 nM
The estimate for compound 3 lay 6.1-fold (0.79 log units) above the measured number, and the stated range ends above it.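

In this assay, for the compounds shown here, 3-fluoro-2-methoxyphenyl in place of 3-methylphenyl on the amide-type nitrogen in the ring gives a 3.6-fold lower number from compound 2 to compound 3 (0.55 log units; beyond the scatter), which is the first readable step and runs toward stronger inhibition. This position therefore accepts a substituted aryl group with 9 heavy atoms and 1 hydrogen-bond acceptor in place of one with 7 heavy atoms and none, and inhibition is not lost when the rest of the molecule stays unchanged. Nothing measured on these compounds bears on why the number falls with this change.

Fluorine and methoxy enter together, so the step cannot be assigned to either until 3-fluorophenyl and 2-methoxyphenyl are compared separately on the same scaffold. Going by these compounds alone, for compound 1 the entry > 1000 nM is a limit of the assay, and this compound differs from the others in more than one place, so no step to it can be read.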